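A few compounds are considered here, and "the series" means these few. Any claim that something is new, unique, unknown or untested is made for them only; others in the source may bear on it.

Working notes on the series in an ADME assay on Vero cells (Chlorocebus sabaeus) for cytotoxicity, read by neutral red uptake, tested at 197 ug/mL; a lower number here means a stronger effect, a higher number a weaker effect of the compound at the concentration tested. Compound 1 `O=C1CSC(c2ccc(Cl)cc2)N1CCN1CCCCC1` gives 68%. Compound 2 `O=C1CSC(c2c(Cl)cccc2Cl)N1CCN1CCCCC1` gives 75%. Compound 3 `O=C1CSC(c2ccccc2[N+](=O)[O-])N1CCN1CCCCC1` gives 100%. Among these three numbers compound 1 stands lowest; its nearest neighbour is compound 2, whose value lies within the usual scatter of it, so the two cannot be ordered, while compound 3 lies beyond the scatter above compound 1 and is the one clearly weaker compound of the set. With three compounds, no more than this is read from the numbers.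

Compound 4 `O=C1CSC(c2cccc(Cl)c2)N1CCN1CCCCC1` has not yet been measured in this assay. It differs from compound 1 as follows: 3-chlorophenyl in place of 4-chlorophenyl on a saturated ring carbon. The two share all their atoms, and the change sits on the saturated ring carbon of the shared core. Nothing in the measured set shows how such a change moves the read-out; the two measured chlorophenyl compounds, compound 1 and compound 2, sit within the scatter of each other. The step is therefore expected to be none beyond the scatter, a number 2 percentage points higher from compound 1 to compound 4 (within the scatter). For compound 4 the value in this assay is estimated at 70%, within a range from 55% to 88%.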

Compound 4, a percentage reported as activity, at one concentration (the size of the read-out at that concentration, not a potency): 77%
Estimate against measurement, compound 4: 7 percentage points below; the measured number falls inside the stated range.
By their numbers in this assay, from the lowest: compounds 1, 2 and 4 (each within the scatter of the next); then compound 3.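

In this assay, 3-chlorophenyl in place of 4-chlorophenyl on a saturated ring carbon gives a number 9 percentage points higher from compound 1 to compound 4 (within the scatter). Among the compounds shown here, this is the first direct one-place comparison, and it shows that this assay does not separate the two chlorine placements on the phenyl group, so compound 1 and compound 4 cannot be ordered. Nothing available accounts for this outcome.

Only chlorine placement has been compared directly at this position, so a single step cannot show how far the read-out tolerates other changes there. As far as these compounds go, whether a 3-methoxyphenyl or a 4-aminophenyl group on the same carbon would stay within the scatter of compound 1 remains open, as does the effect of replacing the chlorine on compound 4 with a carboxylic acid.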